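Lengthening a nitrile chain toward a better-binding analog

The source may report more compounds than this note shows. Statements on the series, on what has been measured and on what is new or still open speak of the compounds shown alone.

Measured compounds:
Compound 1, `CCCc1cc(C(C)=O)c(O)cc1OCCCCC#N`: 37%
Compound 2, `C=CCc1cc(C(C)=O)c(O)cc1OCC#N`: 2%

In an assay on isolated protein for binding affinity to leukotriene B4 receptor 1 (Homo sapiens), tested at 1 uM (on this read-out higher numbers stand for more inhibition at the one concentration tested (going by the name of the read-out) and lower numbers for less inhibition), compound 2 gives the lowest of the two numbers shown, and compound 1 stands well above it, beyond the usual scatter. Compound 3, `C=CCc1cc(C(C)=O)c(O)cc1OCCCC#N`, has not been measured yet. It differs from compound 2 in one place: 2-cyanoethyl in place of cyano on a saturated chain carbon bound to an oxygen on an aromatic ring. Compound 3 carries the longer chain that compound 1 also has, so the step from compound 2 to compound 3 is expected to be a rise of moderate size, a number 16 percentage points higher from compound 2 to compound 3 (beyond the scatter), though the change in the other chain is not covered by the data. Compound 3 is estimated at 18%, within 0% to 40%.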

Compound 3, a percentage reported as inhibition, at one concentration (the size of the read-out at that concentration, not a potency): 6%
For compound 3 the middle estimate is 12 percentage points above the measured one, and the stated range covers the measured number.
By their numbers in this assay, from the lowest: compounds 2 and 3 (each within the scatter of the next); then compound 1.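

In this assay, putting 2-cyanoethyl in place of cyano on the saturated chain carbon bound to an oxygen on an aromatic ring gives a number 4 percentage points higher from compound 2 to compound 3 (within the scatter), so this lengthening, with the rest of the molecule held fixed, leaves the two compounds indistinguishable. Nothing available explains this result.

Compound 1 differs from compound 3 in more than one place, so its number cannot be tied to any single change. Going by these compounds, whether a longer chain or a carboxylic acid in place of the nitrile on the core of compound 3 would separate from compound 3 remains open.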